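A few compounds are considered here, and "the series" means these few. Any claim that something is new, unique, unknown or untested is made for them only; others in the source may bear on it.

Measured compounds in a physicochemical assay for solubility, read by nephelometry, in phosphate buffer, measured as kinetic solubility, at pH 6.5; a higher number here means a more soluble compound, a lower number a less soluble compound:
- compound 1 `CCOC(=O)C1=C(C)N/C(=C/c2cc(C)n(-c3ccc(Br)cc3)c2C)C1=O` gives 2.1 ug/mL
- compound 2 `CCOC(=O)C1=C(C)N/C(=C/c2cc(C)n(-c3ccc(SC(F)(F)F)cc3)c2C)C1=O` gives 1 ug/mL

Compound 1 stands highest of the two numbers; its nearest neighbour is compound 2, and the step of a 2.1-fold lower number from compound 1 to compound 2 (0.32 log units; beyond the scatter) arises from (trifluoromethyl)sulfanyl in place of bromo on an aromatic carbon.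

Compound 3 `CCOC(=O)C1=C(C)N/C(=C/c2cc(C)n(-c3ccncc3)c2C)C1=O` is not yet measured. Its change from compound 1 is pyridin-4-yl in place of 4-bromophenyl on an aromatic nitrogen, in words pyridin-4-yl in place of 4-bromophenyl on an aromatic nitrogen.

Within the data shown here, no measured step covers a change of this kind. Among the measured compounds shown here, the only measured step, from compound 1 to compound 2, alters a substituent on the same aryl ring rather than the ring itself, and it was modest. The expectation for compound 3 therefore rests on the structural difference alone and is loose: compound 3 is estimated at 8 ug/mL, with a range from 2 ug/mL to 30 ug/mL, which corresponds to an expected step of a 3.8-fold higher number from compound 1 to compound 3 (0.58 log units; beyond the scatter).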

Compound 3, solubility: 50 ug/mL
Compound 3: middle estimate off by 6.3-fold (0.80 log units), on the low side; measured number above the stated range.
By their numbers in this assay, from the lowest: compound 2; then compound 1; then compound 3.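

In this assay, exchanging the whole aryl ring on the aromatic nitrogen gives a large step, a 24-fold higher number from compound 1 to compound 3 (1.38 log units; beyond the scatter), whereas the substituent change on that ring gave only a modest one, a 2.1-fold lower number from compound 1 to compound 2 (0.32 log units; beyond the scatter), and in the opposite direction. This position, on an aromatic nitrogen of a five-membered aromatic ring with 1 nitrogen, therefore responds strongly to the identity of the ring it carries, and the entering pyridin-4-yl has one hydrogen-bond acceptor where 4-bromophenyl has none. Nothing measured here connects the step to any property of either group.

Still open, on these data alone, is whether the step depends on the ring nitrogen or would also follow from removing the bromine, which a plain phenyl ring would test. Pyridin-3-yl, or a phenyl ring carrying an amine or a carboxylic acid, would show how far the step extends to other groups at this position.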